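Chloro for methyl on the core of compound 1

The source may hold more compounds than are shown below. What is called first, only, known or untested is meant among the compounds shown, and "the series" means these compounds.

Measured in an ADME assay on MT4 cells (Homo sapiens) for cytotoxicity, read by spectrophotometry, with a stated time of 5 days; a lower number here means that less compound is tolerated, a higher number that more compound is tolerated:
- compound 1 `CONC(=S)N/N=C1\C(=O)N(CN2CCN(c3ccc(Cl)cc3)CC2)c2ccc(C)cc21`: 300000 nM
- compound 2 `CONC(=S)N/N=C1\C(=O)N(CN2CCN(c3ccc(OC)cc3)CC2)c2ccc(C)cc21`: 324000 nM

Compound 1 has a single measured neighbour, and no order can be read between the two. That one step, methoxy in place of chloro on an aromatic carbon, gives a 1.1-fold higher number from compound 1 to compound 2 (0.03 log units; within the scatter).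

Compound 3 `CONC(=S)N/N=C1\C(=O)N(CN2CCN(c3ccc(Cl)cc3)CC2)c2ccc(Cl)cc21` is still unmeasured and carries a different change: chloro in place of methyl on an aromatic carbon. Among the compounds with values here, no step of chloro in place of methyl on an aromatic carbon has been measured, so the only guide is a change made elsewhere in the molecule, and it bears on this one only loosely. On that limited evidence, no step beyond the scatter is expected in this assay, in either direction. The estimated step is a 1.1-fold lower number from compound 1 to compound 3 (0.03 log units; within the scatter). The expected value for compound 3 is 280000 nM, with an expected range of 130000 nM to 450000 nM.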

Compound 3, half-maximal cytotoxic concentration: 229000 nM
The estimate for compound 3 lay 1.2-fold (0.09 log units) above the measured number, within the range that was stated.
By their numbers in this assay, from the lowest: compounds 3, 1 and 2 (each within the scatter of the next).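

In this assay, within the data shown here, the first change on the shared core, chloro in place of methyl on an aromatic carbon, gives a 1.3-fold lower number from compound 1 to compound 3 (0.12 log units; within the scatter) and stays within the scatter. This position therefore joins the methoxy in place of chloro exchange on the other aromatic ring, which gives a 1.1-fold higher number from compound 1 to compound 2 (0.03 log units; within the scatter), as a single change from compound 1 that produces no step beyond the scatter. Nothing available explains the size of the step at this position.

The compounds shown hold only methyl and chloro at this core position, so the effect of an amine, a carboxylic acid or a longer alkyl chain there remains open. Also open, as far as these compounds go, is whether chloro in place of methyl gives a similar step when methoxy stands on the other aromatic ring, since compound 2 carries methoxy only alongside methyl.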